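Working notes: the step from compound 3 to compound 4

The compounds below may be only part of what the source reports. "The series", "measured", "known", "first", "only" and "open" are said of these compounds alone.

Values in a functional assay on HCT-116 cells (Homo sapiens) for cytotoxicity, read by MTT assay, with a stated time of 72 h (a higher number here means a weaker inhibitor, a lower number a stronger inhibitor), so far:
- compound 1 `O=C1c2c[n+]([O-])c3ccccc3c2C(=O)c2c1c1ccccc1n2Cc1cn([C@H]2O[C@H](CO)[C@@H](O)[C@H]2O)nn1` gives 710 nM
- compound 2 `O=C1c2c[n+]([O-])c3ccccc3c2C(=O)c2c1c1ccccc1n2Cc1cn(C[C@H](O)CO)nn1` gives 400 nM
- compound 3 `CC1(C)O[C@@H](CO)[C@H](Cn2cc(Cn3c4c(c5ccccc53)C(=O)c3c[n+]([O-])c5ccccc5c3C4=O)nn2)O1` gives 130 nM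
- compound 4 `O=C1c2c[n+]([O-])c3ccccc3c2C(=O)c2c1c1ccccc1n2Cc1cn([C@H]2C[C@H](O)[C@@H](CO)O2)nn1` is still unmeasured

Compound 3 has the lowest number of the three, and its steps to both others lie beyond the scatter. The next change puts 4-hydroxy-5-(hydroxymethyl)oxolan-2-yl in place of (5-(hydroxymethyl)-2,2-dimethyl-1,3-dioxolan-4-yl)methyl on an aromatic nitrogen and this removes the group that sets compound 3 apart.

For the measured compounds named here, three measured steps bear on this change. The modest 3.1-fold lower number from compound 2 to compound 3 (0.49 log units; beyond the scatter) and a 5.5-fold lower number from compound 1 to compound 3 (0.74 log units; beyond the scatter) both favour compound 3, while a 1.8-fold lower number from compound 1 to compound 2 (0.25 log units; within the scatter) stays within the scatter. The closest guide is compound 1 at 710 nM. It also carries an oxolan-2-yl group on the aromatic nitrogen, though with one more hydroxy group in its name. Going by the values given here, no measured step isolates that difference.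

For compound 4 the expected step is a 3.5-fold higher number from compound 3 to compound 4 (0.54 log units; beyond the scatter) in this assay and points to a higher number, meaning a weaker inhibitor. The estimate for compound  4 is 450 nM with an expected range from 170 nM to 1100 nM for repeat measurements.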

Compound 4, half-maximal inhibitory concentration: 120 nM
Beside the measured number, compound 4's estimate is 3.8-fold (0.57 log units) above it; the whole stated range lies above it.
By their numbers in this assay, from the lowest: compounds 4 and 3 (each within the scatter of the next); then compounds 2 and 1 (each within the scatter of the next).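

In this assay, the step of a 1.1-fold lower number from compound 3 to compound 4 (0.03 log units; within the scatter) shows that the 2,2-dimethyl-1,3-dioxolane group is not needed on this aromatic nitrogen for a number in the range of compound 3, as 4-hydroxy-5-(hydroxymethyl)oxolan-2-yl serves there within the scatter. An oxolan-2-yl group on this nitrogen does not by itself give a high number: the step of a 5.9-fold lower number from compound 1 to compound 4 (0.77 log units; beyond the scatter) lies beyond the scatter, and the two groups differ by one hydroxy group in their names, so this pair points to that hydroxy group or to the different stereocentres as the place where the number changes. The step of a 3.3-fold lower number from compound 2 to compound 4 (0.52 log units; beyond the scatter) also lies beyond the scatter, leaving compound 4 and compound 3 together below the open-chain 2,3-dihydroxypropyl of compound 2, with compound 1 going against any rule that a ring alone gives the lower number.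

No supporting measurement bears on why these groups give different numbers. Open, from the compounds shown here alone, is whether an amine in place of the 4-hydroxy group, or an oxolan-2-yl group with no hydroxy group, would keep the number of compound 4 at 120 nM.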